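A few compounds are considered here, and "the series" means these few. Any claim that something is new, unique, unknown or untested is made for them only; others in the source may bear on it.

Three compounds have been measured so far in a physicochemical assay for solubility, read by turbidimetry, measured as kinetic solubility, at pH 7.4 (on this read-out lower numbers stand for lower solubility and higher numbers for higher solubility), and read as follows:
compound 1 `CC1SC(c2cccc(C(=O)NCCCCc3ccccc3)c2)N(c2ccc(C3CC3)cc2)C1=O` gives 2000 nM
compound 2 `COc1ccc(F)cc1N1C(=O)CSC1c1cccc(C(=O)NCCCCn2cccn2)c1` gives 50000 nM
compound 3 `COc1ccccc1N1C(=O)CSC1c1cc(F)cc(C(=O)NCCCCc2ccccc2)c1` gives 10000 nM

Compound 2 has the highest number of the three, and its gaps to both others lie beyond the scatter. Compound 4 `COc1ccc(F)cc1N1C(=O)CSC1c1cccc(C(=O)NCCCCc2ccccc2)c1` carries phenyl in place of 1H-pyrazol-1-yl on a saturated chain carbon, four bonds along the chain from an amide-type nitrogen. Among the measured compounds shown here, no measured pair isolates this change. Compound 3 (10000 nM) and compound 1 (2000 nM) also bear that phenyl and both stand lower in this assay than compound 2, though their other parts differ. A downward step beyond the scatter is therefore expected, estimated as a 6.3-fold lower number from compound 2 to compound 4 (0.80 log units; beyond the scatter) here. Compound 4 is expected near 8000 nM with an estimated range from 3000 nM to 20000 nM in this read-out.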

Compound 4, solubility: 10000 nM
For compound 4 the middle estimate is 1.3-fold (0.10 log units) below the measured one, within the range that was stated.
By their numbers in this assay, from the lowest: compound 1; then compounds 3 and 4 (each within the scatter of the next); then compound 2.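

With the rest of the molecule unchanged, putting phenyl in place of 1H-pyrazol-1-yl on a saturated chain carbon, four bonds along the chain from an amide-type nitrogen, gives a 5.0-fold lower number from compound 2 to compound 4 (0.70 log units; beyond the scatter) in this assay and lies beyond the usual scatter. Among the compounds shown here, the earlier compounds differed in other parts as well, so this is the first direct reading of this single change. Nothing available explains the step. From the compounds shown here alone, whether it would recur on the core of compound 1 remains open. So does the result of placing an amine or a carboxylic acid at this position.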